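The source may report more compounds than this note shows. Statements on the series, on what has been measured and on what is new or still open speak of the compounds shown alone.

In a functional assay on HCT-116 cells (Homo sapiens) for cytotoxicity, read by MTT assay, with a stated time of 96 h (a lower number here means a stronger inhibitor, a higher number a weaker inhibitor), compound 1 `O=Cc1cc(Br)c(O)c(O)c1Br` gives "not determined" (no result reported). For the measured compounds named here, compound 2 `COCc1cc(Br)c(O)c(O)c1Br` carries the only number: in this assay compound 2 gives 3480 nM, and with nothing beside it no ranking within the set can be drawn. Compound 3 `CCOCc1cc(Br)c(O)c(O)c1Br` differs from compound 2 by methyl in place of hydrogen on a saturated chain carbon bound to an oxygen on a saturated carbon. No measured step of this kind exists among the compounds shown. The change from methoxymethyl to ethoxymethyl is modest, and the step expected, a 1.2-fold lower number from compound 2 to compound 3 (0.06 log units; within the scatter), is one that stays within the usual scatter, in no settled direction. Compound 3 is accordingly estimated at 3000 nM in this assay, with a range from 1200 nM to 8000 nM.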

Compound 3, half-maximal inhibitory concentration: 1540 nM
The estimate for compound 3 lay 1.9-fold (0.29 log units) above the measured number; the range from low to high includes it.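

In this assay, for the compounds shown here, the change from methoxymethyl to ethoxymethyl gives the first measured step (a 2.3-fold lower number from compound 2 to compound 3 (0.35 log units; beyond the scatter)). This shows that the number responds to methyl in place of hydrogen at this position, which compound 2 alone could not show. No measurement shown accounts for this step.

From the compounds shown here alone, a single step sets no trend, so it remains open whether a longer chain such as propoxymethyl would extend the change or reverse it. Also open, going by these compounds, is how hydroxymethyl or an aminomethyl group would compare with the ethers at this place.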